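This account rests on a few compounds, and the source may have more. Where it says the series, first, only, none or still open, it means among the compounds named here.

Measured so far:
- Compound 1 `Cc1cc(/N=c2\[nH]c(=O)n(C[C@H](C)C(=O)O)c(=O)n2Cc2ccc(Cl)cc2)ccc1OC(C)C` gives 102%
- Compound 2 `CC(C)Oc1ccc(/N=c2\[nH]c(=O)n(C[C@@H](O)CO)c(=O)n2Cc2ccc(Cl)cc2)cc1Cl` gives 63%
- Compound 3 `C[C@@H](Cn1c(=O)[nH]/c(=N\c2ccc(Oc3cncc(F)c3)cc2)n(Cc2ccc(Cl)cc2)c1=O)C(=O)O` gives 74.3%

In an ADME assay on the whole organism (Rattus norvegicus) for pharmacokinetics, using cassette dosing, at a dose of 1 mg/kg by the oral route (on this read-out higher numbers stand for higher oral bioavailability and lower numbers for lower oral bioavailability), compound 3 reaches 74.3% and stands second highest of the three. Compound 1 lies higher and compound 2 lower, and each gap is beyond the usual scatter of repeated measurements.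

Compound 4 `C[C@@H](Cn1c(=O)[nH]/c(=N\c2ccc(Oc3cccc(F)n3)cc2)n(Cc2ccc(Cl)cc2)c1=O)C(=O)O` has the same atoms as compound 3, joined differently. On an oxygen on an aromatic ring, 6-fluoropyridin-2-yl stands in place of 5-fluoropyridin-3-yl (6-fluoropyridin-2-yl in place of 5-fluoropyridin-3-yl on an oxygen on an aromatic ring).

Among the compounds with values here, no two of the measured compounds differ in only one place, so the data contain no measured step that shows what a swap of this kind does. The best starting point is therefore compound 3 at 74.3% as the closest measured relative of compound 4. No step beyond the scatter is expected in this assay and neither direction is favoured. The estimated step is a number 2.3 percentage points lower from compound 3 to compound 4 (within the scatter) and it is expected to stay within the scatter. The range is kept wide since so few measurements are available. Expected for compound 4 is 72% within an estimated range from 47% to 97% on this read-out.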

Compound 4, oral bioavailability: 60%
Estimate against measurement, compound 4: 12 percentage points above, within the range that was stated.
By their numbers in this assay, from the lowest: compounds 4 and 2 (each within the scatter of the next); then compound 3; then compound 1.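

Within the data shown here, this is the first measured pair that differs in one place only, and it shows that the group on the oxygen matters in this assay: putting 6-fluoropyridin-2-yl in place of 5-fluoropyridin-3-yl gives a number 14.3 percentage points lower from compound 3 to compound 4 (beyond the scatter). The two groups have the same heavy atoms, the same ring size and the same counts of hydrogen-bond donors and acceptors, so these counts do not separate them. Rejoining the same atoms is therefore enough to move oral bioavailability by more than the usual scatter, and nothing available explains the drop.

This single pair cannot show whether the same swap would have a similar effect on a different core or side chain, so it sets no general rule. The compounds shown also leave open where other groups on this oxygen would fall, such as an unsubstituted phenyl ring, or a pyridine ring carrying a nitrile or a methoxy group instead of the fluorine.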